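The source may hold more compounds than are shown below. What is called first, only, known or untested is meant among the compounds shown, and "the series" means these compounds.

Compound 1 `O=C1c2ccccc2C(=O)N1CCOC(=S)N(C(=O)c1ccc(C(F)(F)F)cc1)c1ccc(Cl)cc1` was tested in an ADME assay on MT4 cells (Homo sapiens) for cytotoxicity, read by MTT assay (on this read-out higher numbers stand for lower toxicity in this test and lower numbers for higher toxicity in this test), where compound 1 gives 10000 nM. That is the lower of the two numbers recorded; compound 2 `Cc1ccc(N(C(=O)c2ccccc2[N+](=O)[O-])C(=S)OCCN2C(=O)c3ccccc3C2=O)cc1` gives 100000 nM in this assay, a gap that lies beyond the usual scatter. Compound 3 `Cc1cc(C(=O)N(C(=S)OCCN2C(=O)c3ccccc3C2=O)c2ccc(Cl)cc2)ccc1Br` differs from compound 1 in one place: 4-bromo-3-methylphenyl in place of 4-(trifluoromethyl)phenyl on a carbonyl carbon. Among the measured compounds shown here, no comparable step between measured compounds is available, so the outcome for compound 3 rests on the structural change alone. The author expects a step from compound 1 to compound 3 of a 1.5-fold higher number from compound 1 to compound 3 (0.18 log units; within the scatter), small and toward a higher number, likely within the scatter. Compound 3 is estimated at 15000 nM, with a range from 5000 nM to 60000 nM.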

Compound 3, half-maximal cytotoxic concentration: 18000 nM
The estimate for compound 3 lay 1.2-fold (0.08 log units) below the measured number; measured number inside the range.
By their numbers in this assay, from the lowest: compounds 1 and 3 (each within the scatter of the next); then compound 2.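

In this assay, 4-bromo-3-methylphenyl in place of 4-(trifluoromethyl)phenyl on a carbonyl carbon gives a 1.8-fold higher number from compound 1 to compound 3 (0.26 log units; within the scatter), so at this position the exchange leaves a difference that cannot be told from the scatter. Among the compounds shown here, this is the first comparison here between compounds that differ in one place, and it covers only this one pair of groups. Nothing measured bears on why the result came out this way. The compounds shown leave open how an amine or a carboxylic acid in place of 4-(trifluoromethyl)phenyl on a carbonyl carbon would read.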